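A few compounds are considered here, and "the series" means these few. Any claim that something is new, unique, unknown or untested is made for them only; others in the source may bear on it.

Compound 2 `CC(=O)OC[C@H]1O[C@@H](n2cc(-c3cn(Cc4ccc(C(C)C)cc4)nn3)c(=O)[nH]c2=O)C[C@@H]1OC(C)=O` gives 92.2% in a functional assay on ACHN cells (Homo sapiens) for cytotoxicity, read by sulforhodamine B assay, tested at 10 uM; a lower number here means less inhibition, a higher number more inhibition at the concentration tested (going by the name of the read-out). Among the three measured numbers, compound 1 `CCCCCc1cc(-c2cn([C@H]3C[C@H](OC(C)=O)[C@@H](COC(C)=O)O3)c(=O)[nH]c2=O)on1` gives 99.8%, within the scatter of compound 2, while compound 3 `CC(=O)OC[C@H]1O[C@@H](n2cc(-c3cc(-c4ccc(C(C)(C)C)cc4)no3)c(=O)[nH]c2=O)C[C@@H]1OC(C)=O` gives 74.7%, beyond the scatter below compound 2. Going by the values given here, the only step between compounds that differ in one place, a number 25.1 percentage points lower from compound 1 to compound 3 (beyond the scatter), shows that a change at this outer position can shift the read-out by a modest amount. Compound 4 `CC(=O)OC[C@H]1O[C@@H](n2cc(-c3cn(Cc4ccccc4)nn3)c(=O)[nH]c2=O)C[C@@H]1OC(C)=O` differs from compound 2 by hydrogen in place of isopropyl on an aromatic carbon. Among the compounds with values here, no measured step removes a small alkyl group in this way, so that evidence bears only loosely; a modest loss is expected, a number 10.2 percentage points lower from compound 2 to compound 4 (beyond the scatter). Compound 4 is therefore estimated at 82%, within a range from 60% to 97%.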

Compound 4, a percentage reported as inhibition, at one concentration (the size of the read-out at that concentration, not a potency): 99%
Compound 4: middle estimate off by 17 percentage points, on the low side, and the stated range ends below it.
By their numbers in this assay, from the lowest: compound 3; then compounds 2, 4 and 1 (each within the scatter of the next).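

Replacing isopropyl with hydrogen on the aromatic carbon gives a number 6.8 percentage points higher from compound 2 to compound 4 (within the scatter) in this assay, so 4-isopropylbenzyl and plain benzyl cannot be told apart in this read-out. Going by these compounds alone, the isopropyl group is therefore not required to keep the number high in this pair, a point the earlier compounds could not show. No measurement offered here accounts for this result. The compounds shown leave open whether an amine, a carboxylic acid or a longer alkyl chain on this aromatic carbon would keep the read-out or shift it beyond the scatter.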